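A few compounds are considered here, and "the series" means these few. Any claim that something is new, unique, unknown or untested is made for them only; others in the source may bear on it.

Measured so far:
- Compound 1 `O=C1O[C@@H](CO)CN1c1ccc(-n2cc(-c3ccccn3)cn2)c(F)c1`: > 400 ug/mL in an ADME assay on HEK293-A cells (Homo sapiens) for cytotoxicity, read by MTT assay, with a stated time of 48 h (on this read-out higher numbers stand for weaker inhibition and lower numbers for stronger inhibition), a limit of the assay.
- Compound 2 `CN(CCC#N)C[C@H]1CN(c2ccc(-n3cc(-c4ccccn4)cn3)c(F)c2)C(=O)O1`: > 400 ug/mL in this assay, a limit.
- Compound 3 `O=C(OC[C@H]1CN(c2ccc(-n3cc(-c4ccccn4)cn3)c(F)c2)C(=O)O1)c1ccccc1`: > 400 ug/mL in this assay, a limit.

Compound 3 thus stands at the limit of > 400 ug/mL in this assay, at which 3 of the 3 values shown sit; no number is known for it, only this limit. Compound 4 `CCNC(=O)NC[C@H]1CN(c2ccc(-n3cc(-c4ccccn4)cn3)c(F)c2)C(=O)O1` differs from compound 3 in one place: (ethylcarbamoyl)amino in place of benzoyloxy on a saturated chain carbon bound to a saturated ring carbon. Within the data shown here, the steps that bear on this position, a step that the two limits leave unreadable from compound 1 to compound 3 and a step that the two limits leave unreadable from compound 2 to compound 3, and likewise a step that the two limits leave unreadable from compound 1 to compound 2, are all unreadable, so no size of step in this assay can be taken from them. Since each of the three measured compounds returned only a limit, the step that the limit leaves unreadable from compound 3 to compound 4 is expected to show nothing readable either. Compound 4 is expected near 500 ug/mL, in a range from 300 ug/mL to 1000 ug/mL, and most likely reported again only as a limit.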

Compound 4, half-maximal inhibitory concentration: 29 ug/mL
The estimate for compound 4 lay 17-fold (1.24 log units) above the measured number, outside the stated range (below it).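

In this assay, the group on the saturated chain carbon bound to a saturated ring carbon can move the read-out out of the limit: (ethylcarbamoyl)amino gives an at least 13-fold lower number from compound 3 to compound 4 (1.13 log units; beyond the scatter), an at least 13-fold lower number from compound 2 to compound 4 (1.13 log units; beyond the scatter) and an at least 13-fold lower number from compound 1 to compound 4 (1.13 log units; beyond the scatter). Among these compounds, this is the first number, so the lower number stands for stronger inhibition of these cells with the core of compound 1 unchanged. The steps among compound 1, compound 2 and compound 3 cannot be read, as each of these compounds returns only a limit: the limit of > 400 ug/mL in this assay, at which 3 of the 4 values shown sit.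

As far as these compounds go, whether the whole (ethylcarbamoyl)amino group is needed stays open. An acetylamino group, or a longer chain in place of the ethyl, would test this.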